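Notes on the step from compound 3 to compound 4

This account rests on a few compounds, and the source may have more. Where it says the series, first, only, none or still open, it means among the compounds named here.

compound 1 `Cc1cc(-c2cccc3cc[nH]c23)cc(C)c1Nc1ccnc(Nc2ccc(C#N)cc2)n1`: 1000 nM
compound 2 `Cc1csc(-c2cc(C)c(Nc3ccnc(Nc4ccc(C#N)cc4)n3)c(C)c2)c1`: 34000 nM
compound 3 `Cc1cc(-c2ccnc(F)c2)cc(C)c1Nc1ccnc(Nc2ccc(C#N)cc2)n1`: 6000 nM

In a toxicity assay on MT4 cells (Homo sapiens) for cytotoxicity, read by MTT assay, with a stated time of 5 days (on this read-out higher numbers stand for lower toxicity in this test and lower numbers for higher toxicity in this test), compound 3 gives 6000 nM, the second highest of the three numbers. Compound 4 `Cc1ncc(-c2cc(C)c(Nc3ccnc(Nc4ccc(C#N)cc4)n3)c(C)c2)cn1` carries 2-methylpyrimidin-5-yl in place of 2-fluoropyridin-4-yl on an aromatic carbon. Three measured steps change this same place: a 34-fold higher number from compound 1 to compound 2 (1.53 log units; beyond the scatter), a 6.0-fold higher number from compound 1 to compound 3 (0.78 log units; beyond the scatter) and a 5.7-fold lower number from compound 2 to compound 3 (0.75 log units; beyond the scatter). The first is large and the other two modest, so this place can move the number considerably. None of them involves 2-methylpyrimidin-5-yl, which leaves the direction poorly defined. A small upward shift in this assay is expected, possibly none beyond the scatter. The expected change is a 1.3-fold higher number from compound 3 to compound 4 (0.12 log units; within the scatter). For compound 4 the estimate is 8000 nM, with an expected range of 2500 nM to 26000 nM.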

Compound 4, half-maximal cytotoxic concentration: 3900 nM
The estimate for compound 4 lay 2.1-fold (0.31 log units) above the measured number; the range from low to high includes it.
By their numbers in this assay, from the lowest: compound 1; then compounds 4 and 3 (each within the scatter of the next); then compound 2.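

In this assay, the exchange of 2-fluoropyridin-4-yl for 2-methylpyrimidin-5-yl at this position gives a 1.5-fold lower number from compound 3 to compound 4 (0.19 log units; within the scatter), so a second hetero atom in the six-membered aromatic ring, with methyl replacing fluorine, leaves no change beyond the scatter. The same group gives an 8.7-fold lower number from compound 2 to compound 4 (0.94 log units; beyond the scatter) and a 3.9-fold higher number from compound 1 to compound 4 (0.59 log units; beyond the scatter), which places compound 4, like compound 3, between the 4-methylthiophen-2-yl and 1H-indol-7-yl compounds. No measured evidence bears on why this position responds in this way. Going by these compounds, the effect of an amine or a carboxylic acid on this aromatic carbon remains open.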